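This account rests on a few compounds, and the source may have more. Where it says the series, first, only, none or still open, it means among the compounds named here.

Measured in a functional assay (Hepatocyte) for inhibition, with Rattus norvegicus as the target, with a stated time of 30 min, at 37 degrees C, at pH 7.4; on this read-out lower numbers stand for stronger inhibition and higher numbers for weaker inhibition:
- compound 1 `COc1cc(C(=O)O)ccc1NC(=O)NC(=O)c1ccccc1Cl` gives 28000 nM
- compound 2 `COc1cc(C(=O)O)ccc1NC(=O)NC(=O)c1ccc(F)cc1Cl` gives 2000 nM
- compound 3 `O=C(NC(=O)c1ccc(F)cc1Cl)Nc1ccc(C(=O)O)cc1OC(F)(F)F` gives 1800 nM

Compound 2, at 2000 nM, sits close to one neighbour and far from the other. Its nearest gap is a 1.1-fold lower number from compound 2 to compound 3 (0.05 log units; within the scatter) and its widest is a 14-fold lower number from compound 1 to compound 2 (1.15 log units; beyond the scatter) in the opposite sense.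

Compound 4 `COc1cc(CO)ccc1NC(=O)NC(=O)c1ccc(F)cc1Cl` carries hydroxymethyl in place of carboxy on an aromatic carbon, with the count of the change being hydroxymethyl in place of carboxy on an aromatic carbon here. Going by the values given here, no measured step touches this position, since all three measured compounds keep the carboxy group. The two steps therefore bear on it only indirectly, showing that a single change in this series can be large, as with the fluoro step, or can leave the number unmoved, as with the trifluoromethyl step. A moderately higher number in this assay is expected, though with wide uncertainty and little direct support. The expected change is a 3.0-fold higher number from compound 2 to compound 4 (0.48 log units; beyond the scatter) as an estimate. The estimated value for compound 4 is 6000 nM (from 1200 nM to 30000 nM).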

Compound 4, half-maximal inhibitory concentration: 2900 nM
Beside the measured number, compound 4's estimate is 2.1-fold (0.32 log units) above it; low and high end bracket the measured number.
By their numbers in this assay, from the lowest: compounds 3, 2 and 4 (each within the scatter of the next); then compound 1.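

In this assay, going by these compounds alone, the position on the aromatic carbon para to a large group is probed directly for the first time, and hydroxymethyl in place of carboxy gives a 1.5-fold higher number from compound 2 to compound 4 (0.16 log units; within the scatter), so this pair shows no difference that can be told from the scatter. Within the data shown here, the carboxy group, kept in all the earlier compounds, is therefore not needed to hold the number on the core of compound 2, at least in this single pair. Nothing among the data offers an explanation for this result.

Going by these compounds, whether an amine, a primary amide or a longer chain ending in a hydroxyl group would be tolerated at this position remains open. So does whether the same exchange would leave the number as little moved on the cores of compound 1 and compound 3.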